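This account rests on a few compounds, and the source may have more. Where it says the series, first, only, none or still open, it means among the compounds named here.

Series notes. Compound 1 `COc1ccc(/C=C/C2(C)C=CC(=O)O2)c(OC)c1` gives 151000 nM in a functional assay on NCI/ADR-RES cells (Homo sapiens) for inhibition, read by sulforhodamine B assay, with a stated time of 48 h; on this read-out lower numbers stand for stronger inhibition of growth and higher numbers for weaker inhibition of growth. Compound 2 `COc1ccc(/C=C/C2(C)C=CC(=O)O2)cc1OC` gives 111000 nM in this assay; the difference between the cores of compound 1 and compound 2 is not broken down here. Compound 3 `COc1cc(/C=C/C2(C)C=CC(=O)O2)cc(OC)c1OC` gives 123000 nM in this assay. The change from compound 2 to compound 3 is methoxy in place of hydrogen on an aromatic carbon and produced a 1.1-fold higher number from compound 2 to compound 3 (0.04 log units; within the scatter). Compound 4 `COc1cc(OC)c(/C=C/C2(C)C=CC(=O)O2)c(OC)c1` is not yet measured; it arises from compound 1 by the same kind of change, (methoxy in place of hydrogen on an aromatic carbon), though here the entering group sits ortho to the group of 9 heavy atoms and meta to two methoxy groups, whereas in the earlier case it sat ortho to a methoxy group and meta to the group of 9 heavy atoms. Because the earlier step was a 1.1-fold higher number from compound 2 to compound 3 (0.04 log units; within the scatter), the step from compound 1 to compound 4 is expected to be a 1.1-fold higher number from compound 1 to compound 4 (0.04 log units; within the scatter). Compound 4 is therefore estimated at 165000 nM in this assay, expected between 85000 nM and 330000 nM.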

Compound 4, concentration for total growth inhibition: 229000 nM
Beside the measured number, compound 4's estimate is 1.4-fold (0.14 log units) below it, and the stated range covers the measured number.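

On the core of compound 1, methoxy in place of hydrogen on an aromatic carbon gives a 1.5-fold higher number from compound 1 to compound 4 (0.18 log units; within the scatter) in this assay. Set beside the earlier step, the change carries across these two cores with no difference that can be read: the same change on two cores in this assay, a 1.1-fold higher number (0.04 log units; within the scatter) from compound 2 to compound 3 and a 1.5-fold higher number (0.18 log units; within the scatter) from compound 1 to compound 4, 1.4-fold (0.14 log units) apart, within the scatter of two such steps

For the compounds shown here, this shows only that neither step stands out from the scatter on these two cores; it does not show a real effect of the added methoxy, nor that the same would hold on any other core.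

Open, as far as these compounds go, is whether a group other than methoxy on the aromatic ring, such as an amine, a carboxylic acid or a longer alkoxy chain, would give a step beyond the scatter.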